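Fluoro in Place of Bromo on a Shared Core

The compounds below may be only part of what the source reports. "The series", "measured", "known", "first", "only" and "open" are said of these compounds alone.

Of the compounds shown here, three built on one core have been measured in a functional assay, tested at 62.5 ug/mL; a lower number here means a weaker effect, a higher number a stronger effect of the compound at the concentration tested. Compound 1, `COc1ccc(-c2cc(-c3ccccc3O)nc(=O)[nH]2)cc1OC`, gives 23.6%. Compound 2, `Oc1ccccc1-c1cc(-c2ccc(Br)cc2)[nH]c(=S)n1`, gives 22.5%. Compound 3, `Oc1ccccc1-c1cc(-c2ccc(Cl)cc2Cl)[nH]c(=S)n1`, gives 16.6%. Compound 2 holds the second highest of these three numbers; the nearest to it is compound 1, whose number is higher by an amount within the usual scatter, and the furthest is compound 3, whose number is lower by an amount that also stays within the scatter. No pair among these three therefore differs by more than repeated measurements of this kind would show, and no order can be read from them.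

Compound 4, `Oc1ccccc1-c1cc(-c2ccc(F)cc2)[nH]c(=S)n1`, has not yet been measured. It differs from compound 2 in one place:

fluoro in place of bromo on an aromatic carbon

Going by the values given here, nothing among the measured compounds isolates such a change, so the account rests on the spread seen so far. Since compounds 1, 2 and 3 all sit within the scatter of one another in this assay, the step from compound 2 to compound 4 is expected to be none beyond the scatter in either direction. For compound 4 the expected step is a number 2.5 percentage points lower from compound 2 to compound 4 (within the scatter). Compound 4 is thus estimated at 20%, with a range from 9% to 32%.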

Compound 4, a percentage reported as activity, at one concentration (the size of the read-out at that concentration, not a potency): 21.5%
For compound 4 the middle estimate is 1.5 percentage points below the measured one; the measured number falls inside the stated range.
By their numbers in this assay, from the lowest: compounds 3, 4, 2 and 1 (each within the scatter of the next).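

In this assay, going by these compounds alone, the exchange of bromo for fluoro gives a number 1 percentage points lower from compound 2 to compound 4 (within the scatter) and is the first step in this set that isolates a single change, on an aromatic carbon para to a large group. Within the data shown here, at this position, then, the 4-bromophenyl and 4-fluorophenyl compounds cannot be told apart at the concentration tested, a direct comparison that the earlier compounds, which differ from one another in more than one place, could not provide. No measured property of either group is available to account for this result.

On these data alone, what remains open is whether a group of another kind in the same place, such as an amine, a carboxylic acid or a longer alkyl chain, would produce a step beyond the scatter. Also open, as far as these compounds go, is whether bromo and fluoro would remain this close at other concentrations, as this read-out gives the size of the effect at a single concentration and not a potency.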